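A few compounds are considered here, and "the series" means these few. Any claim that something is new, unique, unknown or untested is made for them only; others in the source may bear on it.

Measured compounds:
Compound 1 `C[C@@H](O)CCn1nc2c(Br)c(Br)c(Br)c(Br)c2n1` gives 71% in a functional assay on CCRF-CEM cells (Homo sapiens) for antiproliferative activity, read by MTT assay, with a stated time of 48 h, tested at 25 uM; on this read-out lower numbers stand for a stronger effect and higher numbers for a weaker effect at the one concentration tested.
Compound 2 `OC(CCn1nc2c(Br)c(Br)c(Br)c(Br)c2n1)c1ccccc1` gives 84% in this assay.

Of these two numbers, compound 1 has the lower, which on this read-out is the stronger effect; compound 2 sits a step higher that lies beyond the usual scatter. The next compound, compound 3 `C[C@H](O)CCn1nc2c(Br)c(Br)c(Br)c(Br)c2n1`, has not yet been measured. Compared with compound 1, (the two compounds have the same atoms and bonds and differ only in configuration as drawn: 1 of 1 stereo elements differ; a stereocentre at a saturated chain carbon is drawn R in compound 1 and S in compound 3). Among the measured compounds shown here, no measured pair here shows what such a change in configuration alone does, so the step is expected to be none beyond the scatter, and the value expected from compound 1 to compound 3 is a number 1 percentage points higher from compound 1 to compound 3 (within the scatter). Compound 3 is therefore estimated at 72%, within a range from 55% to 88%.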

Compound 3, a percentage reported as activity, at one concentration (the size of the read-out at that concentration, not a potency): 89%
Compound 3: the middle estimate sits 17 percentage points below what was measured, outside the stated range (above it).
By their numbers in this assay, from the lowest: compound 1; then compounds 2 and 3 (each within the scatter of the next).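

Configuration alone matters at this position: in this assay, redrawing the saturated chain carbon from R to S gives a number 18 percentage points higher from compound 1 to compound 3 (beyond the scatter), a weaker effect at the one concentration tested. The earlier compounds shown here offered no pair of this kind. The step can be assigned to this stereocentre alone because of one fact: the fact that compounds 1 and 3 differ only in the configuration as drawn.

Still open, going by these compounds, is whether an amine in place of the hydroxyl, or a longer chain, would keep this gap between the two configurations. Compound 2 is drawn without a stated configuration, so it cannot settle whether the same preference holds with a phenyl group.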